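5-Hydroxytryptamine 1D agonists: amine substituent series, compound 4

This account rests on a few compounds, and the source may have more. Where it says the series, first, only, none or still open, it means among the compounds named here.

Measured compounds and their largest responses in a functional assay on CHO cells for activation of 5-hydroxytryptamine receptor 1D (Homo sapiens), read by GTPgammaS binding; a higher number here means a larger maximal response, a lower number a smaller maximal response:
compound 1, `c1ccc(C2CCCCN2C2CCN(CCCc3c[nH]c4ccc(-n5cnnc5)cc34)CC2)cc1`: 65%
compound 2, `CN(Cc1cccs1)C1CCN(CCCc2c[nH]c3ccc(-n4cnnc4)cc23)CC1`: 81%
compound 3, `O[C@@H]1Cc2ccccc2[C@H]1NC1CCN(CCCc2c[nH]c3ccc(-n4cnnc4)cc23)CC1`: 75%

Compound 3 stands second of the three numbers in this assay. Its nearest neighbour is compound 2, and the step of a number 6 percentage points lower from compound 2 to compound 3 (within the scatter) lies within the scatter; the gap to compound 1 is likewise within the scatter. On these numbers the three amine substituents on the shared core are not separated.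

Compound 4, `CC(=O)Nc1ccc(CNC2CCN(CCCc3c[nH]c4ccc(-n5cnnc5)cc34)CC2)cc1`, is the next member. Its change from compound 3: 4-acetamidobenzyl in place of 2-hydroxy-2,3-dihydro-1H-inden-1-yl on an amine nitrogen.

Among the compounds with values here, the only measured step at this position, a number 6 percentage points lower from compound 2 to compound 3 (within the scatter), was within the scatter, and no measured pair carries a 4-acetamidobenzyl group, so no step in either direction beyond the scatter can be read from the data for this assay. The expected step is therefore no change at the digits printed from compound 3 to compound 4 (within the scatter), essentially none beyond the scatter.

Compound 4 is estimated to give 75% in this assay, with a range from 60% to 90%.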

Compound 4, largest response reached (reported as efficacy), in percent of the reference or control that the assay uses: 75%
Compound 4: the middle estimate sits on the measured number at the digits printed; measured number inside the range.
By their numbers in this assay, from the lowest: compounds 1, 3, 4 and 2 (each within the scatter of the next, the first and the last beyond it).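

In this assay the exchange gives no change at the digits printed from compound 3 to compound 4 (within the scatter), so on this amine nitrogen the 2-hydroxy-2,3-dihydro-1H-inden-1-yl group, with its five-membered non-aromatic ring and 2 defined stereocentres, and the 4-acetamidobenzyl group, with no defined stereocentre, are not separated by maximal response. Unlike the earlier step at this position, this comparison brings in an acetamido group and removes the non-aromatic ring and the stereocentres, yet still gives no step beyond the scatter. No independent data bear on why the response holds across this change.

From the compounds shown here alone, it remains open whether a carboxylic acid or a primary amine in place of the acetamido group would move the response in this assay beyond the scatter. Going by these compounds, a longer chain between the aromatic ring and the amine nitrogen is equally open.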